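The compounds below may be only part of what the source reports. "The series", "measured", "known", "first", "only" and "open" are said of these compounds alone.

Measured so far:
compound 1, `Cc1ccc(-c2n[nH]cc2N2CCCNCC2)cc1`, 892 nM 
compound 2, `Fc1ccc(-c2n[nH]cc2N2CCCNCC2)cc1`, 2190 nM 

Two compounds share one core and differ only in the group on the six-membered aromatic ring of carbon only. In an assay on isolated protein for binding affinity to 5-hydroxytryptamine receptor 1D (Homo sapiens) (a higher number here means a weaker inhibitor, a lower number a stronger inhibitor), compound 1 gives 892 nM, and compound 2 gives 2190 nM, the highest of the two numbers; the change of a 2.5-fold higher number from compound 1 to compound 2 (0.39 log units; beyond the scatter) is modest but beyond the scatter.

Compound 3, `COc1ccc(-c2n[nH]cc2N2CCCNCC2)cc1`, has not yet been measured in this assay. It differs from compound 2 by methoxy in place of fluoro on an aromatic carbon. Among the measured compounds shown here, the only measured step that bears on this is the one from compound 1 to compound 2, which swapped one small group for another at the same place and moved the number by a 2.5-fold higher number from compound 1 to compound 2 (0.39 log units; beyond the scatter). For the measured compounds named here, no step in this set involves methoxy, so the direction for compound 3 rests on the fact that compound 1 with its methyl gave the lower number of the two. On that basis compound 3 is expected to come out somewhat below compound 2, a step of about a 1.8-fold lower number from compound 2 to compound 3 (0.26 log units; within the scatter), which is estimated rather than known. The estimate for compound 3 in this assay is 1200 nM, with a range from 400 nM to 3500 nM.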

Compound 3, inhibition constant: 3030 nM
Compound 3: middle estimate off by 2.5-fold (0.40 log units), on the low side, within the range that was stated.
By their numbers in this assay, from the lowest: compound 1; then compounds 2 and 3 (each within the scatter of the next).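

In this assay, the replacement of fluoro by methoxy gives a 1.4-fold higher number from compound 2 to compound 3 (0.14 log units; within the scatter), so this change, which adds a heavy atom and a hydrogen-bond acceptor, leaves the two compounds indistinguishable. Methoxy in place of methyl gives a 3.4-fold higher number from compound 1 to compound 3 (0.53 log units; beyond the scatter), and this step, together with a 2.5-fold higher number from compound 1 to compound 2 (0.39 log units; beyond the scatter), shows that among the three groups at this place on the six-membered aromatic ring, para to a large group, only the methyl of compound 1 stands apart, and that a hydrogen-bond acceptor on the entering group does not bring the number back toward that of compound 1. No measurement in hand explains why methyl stands apart from fluoro and methoxy.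

The three compounds leave open whether this separation belongs to methyl alone or would extend to other carbon groups such as ethyl or trifluoromethyl, and how a chloro group, an amine or a carboxylic acid would behave at the same place. They also leave open whether methyl, fluoro and methoxy would keep this relation at another carbon of the ring or on a different shared core.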